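This account rests on a few compounds, and the source may have more. Where it says the series, first, only, none or still open, it means among the compounds named here.

Measured in a functional assay on LNCaP cells (Homo sapiens) for antiproliferative activity; on this read-out higher numbers stand for weaker inhibition and lower numbers for stronger inhibition:
- compound 1 `Cn1ncc(Cl)c1-c1cc(C(=O)N[C@@H]2CN[C@H](CCNS(C)(=O)=O)C[C@H]2c2ccc(F)c(F)c2)oc1Cl`: 50 nM
- compound 2 `CC(=O)NCC[C@@H]1C[C@@H](c2ccc(F)c(F)c2)[C@H](NC(=O)c2cc(-c3c(Cl)cnn3C)c(Cl)o2)CN1`: 130 nM

Of these two compounds, compound 2 has the higher number at 130 nM. The gap is a modest one, beyond the scatter.

Next in the series is compound 3 `CNC(=O)C[C@@H]1C[C@@H](c2ccc(F)c(F)c2)[C@H](NC(=O)c2cc(-c3c(Cl)cnn3C)c(Cl)o2)CN1`. The change is methylcarbamoyl in place of acetamidomethyl on a saturated chain carbon bound to a saturated ring carbon, with methylcarbamoyl in place of acetamidomethyl on a saturated chain carbon bound to a saturated ring carbon. The same difference can also be read as 2-acetamidoethyl to (methylcarbamoyl)methyl.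

Going by the values given here, only one measured step is available: a 2.6-fold higher number from compound 1 to compound 2 (0.41 log units; beyond the scatter), with acetyl in place of methylsulfonyl on an amine nitrogen. It bears on this change only indirectly, since it alters the end of the side chain and leaves the chain itself untouched. Among the compounds with values here, no measured step covers the present change, and the data do not fix a direction. A step of similar modest size is therefore the most that can be expected in this assay, with a slight lean to a higher number. The estimated step is a 1.2-fold higher number from compound 2 to compound 3 (0.09 log units; within the scatter), so no shift beyond the scatter is expected. For compound 3 the expected value is 160 nM, with an estimated range of 55 nM to 450 nM.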

Compound 3, half-maximal inhibitory concentration: 50 nM
For compound 3 the middle estimate is 3.2-fold (0.51 log units) above the measured one, outside the stated range (below it).
By their numbers in this assay, from the lowest: compounds 1 and 3 (each within the scatter of the next); then compound 2.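

In this assay, going by these compounds alone, replacing 2-acetamidoethyl with (methylcarbamoyl)methyl on the saturated ring carbon gives a 2.6-fold lower number from compound 2 to compound 3 (0.41 log units; beyond the scatter) and is the first measured change to the side chain itself, as the earlier step altered only the group at its end. The comparison with the sulfonamide-bearing side chain gives no change at the digits printed from compound 1 to compound 3 (within the scatter), so two differently built side chains cannot be told apart on this read-out, while compound 2 goes against any reading that all three side chains perform alike. No supporting measurement bears on the origin of either step.

The step from compound 2 to compound 3 changes the chain and the way the amide is attached in a single move, so the compounds shown do not separate the contribution of each. Also open, going by these compounds, is how this assay responds at this position to a 2-(methylcarbamoyl)ethyl chain, which would keep the methylcarbamoyl group on a longer chain, or to an amine or a carboxylic acid at the end of the side chain.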